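Diethylamide to Pyrrolidine Amide: Expected Half-Life of Compound 3

The source may hold more compounds than are shown below. What is called first, only, known or untested is meant among the compounds shown, and "the series" means these compounds.

Measured so far:
Compound 1 `CCCCCOC(=O)N1CCN(C(=O)[C@H](CCC(=O)O)NC(=O)c2cc(N3CCC(C(=O)N(CC)CC)CC3)nc(-c3ccccc3)n2)CC1` gives 0.00667 h
Compound 2 `CCCCCOC(=O)N1CCN(C(=O)[C@H](CCC(=O)O)NC(=O)c2cc(N3CCC(C(=O)NCC)CC3)nc(-c3ccccc3)n2)CC1` gives 0.005 h

In an in vivo ADME assay on the whole organism (strain Sprague-Dawley) for metabolic stability, with Rattus norvegicus as the target (on this read-out higher numbers stand for a longer-lived compound and lower numbers for a shorter-lived compound), compound 1 gives 0.00667 h and compound 2 gives 0.005 h. The step of a 1.3-fold lower number from compound 1 to compound 2 (0.13 log units; within the scatter) is within the scatter, so on this read-out compound 1 and compound 2 cannot be told apart, and neither can be called the longer-lived one.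

Compound 3 `CCCCCOC(=O)N1CCN(C(=O)[C@H](CCC(=O)O)NC(=O)c2cc(N3CCC(C(=O)N4CCCC4)CC3)nc(-c3ccccc3)n2)CC1` differs from compound 1 by pyrrolidin-1-yl in place of diethylamino on a carbonyl carbon. Within the data shown here, the only measured step available lies in the same part of the molecule, on the nitrogen of that amide, and it was a 1.3-fold lower number from compound 1 to compound 2 (0.13 log units; within the scatter), a change that stayed within the scatter. Among the measured compounds shown here, no measured step touches the ring that enters here, so the expectation rests on that single neighbouring step alone.

On this basis the step from compound 1 to compound 3 is expected to be a 1.0-fold higher number from compound 1 to compound 3 (0.02 log units; within the scatter), that is, no change beyond the scatter. In this assay compound 3 is therefore estimated at 0.007 h, with a range from 0.003 h to 0.016 h.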

Compound 3, half-life: 0.0133 h
Beside the measured number, compound 3's estimate is 1.9-fold (0.28 log units) below it; low and high end bracket the measured number.
By their numbers in this assay, from the lowest: compounds 2, 1 and 3 (each within the scatter of the next, the first and the last beyond it).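

In this assay the pyrrolidin-1-yl group on the carbonyl carbon gives a 2.0-fold higher number from compound 1 to compound 3 (0.30 log units; within the scatter) when it replaces diethylamino, so joining the two ethyl arms into a ring, with the same count of heavy atoms, still leaves these two compounds indistinguishable on this read-out. Set against the ethylamino amide, the same ring gives a 2.7-fold higher number from compound 2 to compound 3 (0.42 log units; beyond the scatter) and this is the first modest gap in the series to clear the scatter, showing that the group on this carbonyl carbon can shift the measured half-life, if only slightly. Nothing given here accounts for this difference between the groups.

The compounds shown leave open how a larger ring such as piperidin-1-yl or a morpholin-4-yl group would read on the same carbonyl carbon, and whether a plain amino group there would sit closer to compound 2 or to compound 3. They also leave open whether this modest gap would keep its size if another part of the shared core were changed.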